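Triazolylmethylene butenolides against pancreatic carcinoma cell proliferation

The source may report more compounds than this note shows. Statements on the series, on what has been measured and on what is new or still open speak of the compounds shown alone.

Compound 1 `O=C1O/C(=C\Cn2cc(-c3ccc(Br)cc3)nn2)C(OCc2ccccc2)=C1OCc1ccccc1` in a functional assay on CFPAC-1 cells (Homo sapiens) for antiproliferative activity, read by MTT assay, with a stated time of 72 h (on this read-out higher numbers stand for weaker inhibition and lower numbers for stronger inhibition), gives > 100000 nM, a limit of the assay and not a number.
Compound 2 `O=C1O/C(=C\Cn2cc(-c3cc(F)cc(F)c3)nn2)C(OCc2ccccc2)=C1OCc1ccccc1` in this assay is reported as "not active" (no number reported), with no number.
Compound 3 `COc1ccc(-c2cn(C/C=C3\OC(=O)C(OCc4ccccc4)=C3OCc3ccccc3)nn2)cc1` in this assay gives > 100000 nM, again a limit of the assay.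

Compound 3 therefore stands nowhere in particular among the numbers: its value is a limit, one of two limits in the set, and the third entry carries no number at all. For the measured compounds named here, the one step between measured compounds, a step that the two limits leave unreadable from compound 1 to compound 3, is left unreadable by the two limits, so it gives no size in either direction.

Compound 4 `O=C1O/C(=C\Cn2cc(-c3cccc(O)c3)nn2)C(OCc2ccccc2)=C1OCc1ccccc1` differs from compound 3 by 3-hydroxyphenyl in place of 4-methoxyphenyl on an aromatic carbon. Going by the values given here, no measured step bears on this change with a readable size; the only guidance is that the limit of > 100000 nM in this assay, at which 2 of the 3 values shown sit, holds for the series so far, and the change is small. Compound 4 is expected to stay at that limit, so the step of a number no higher from compound 3 to compound 4 (the limit leaves the size open) is estimated as none beyond the scatter. For compound 4 in this assay the estimate is 100000 nM, within 30000 nM to 300000 nM.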

Compound 4, half-maximal inhibitory concentration: 33700 nM
Compound 4: the middle estimate sits 3.0-fold (0.47 log units) above what was measured; the measured number falls inside the stated range.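

In this assay, for the compounds shown here, compound 4 gives 33700 nM as the first readable number of the series, with 3-hydroxyphenyl on an aromatic carbon of the five-membered aromatic ring with 3 nitrogen. The group at this place can therefore move the read-out, as shown by an at least 2.9-fold lower number from compound 3 to compound 4 (0.47 log units; beyond the scatter) and by an at least 2.9-fold lower number from compound 1 to compound 4 (0.47 log units; beyond the scatter) and both steps start from limits of the assay, so only a lowest size can be read. Readable numbers remain scarce in the set: the limit of > 100000 nM in this assay, at which 2 of the 4 values shown sit.

The change moves the oxygen substituent on the phenyl ring and replaces methoxy with hydroxy together, and the compounds shown do not separate these two, which 4-hydroxyphenyl or 3-methoxyphenyl would address. As far as these compounds go, how 3-aminophenyl or 3-carboxyphenyl at the same place would compare also stays open.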